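Hydroxy to methoxy: a repeated change on two cores

A few compounds are considered here, and "the series" means these few. Any claim that something is new, unique, unknown or untested is made for them only; others in the source may bear on it.

Measured so far:
Compound 1, `CO/N=C(/c1ccc(Cl)cc1)C(O)CN1CCN(c2ccccn2)CC1`: 22.6 nM
Compound 2, `CO/N=C(/c1ccc(Cl)cc1)C(CN1CCN(c2ccccn2)CC1)OC`: 285 nM
Compound 3, `Cc1cccc(/C(=N\O)C(O)CN2CCN(c3ccccn3)CC2)c1`: 44.8 nM

All numbers come from a functional assay on HEK293 cells with D(4) dopamine receptor (Homo sapiens) as the target, read by FLIPR; a higher number here means that more compound is needed for the effect, a lower number that less compound is needed. Compound 1 and compound 2 share a core and differ by methyl in place of hydrogen on an oxygen on a saturated carbon; in this assay the step is a 13-fold higher number from compound 1 to compound 2 (1.10 log units; beyond the scatter). Compound 3 sits on a different core; the difference between the two cores is not broken down here. Compound 3 and compound 1 give values within the scatter of each other, whereas compound 2 is beyond the scatter from both.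

Compound 4, `COC(CN1CCN(c2ccccn2)CC1)/C(=N/O)c1cccc(C)c1`, is not yet measured. Within the data shown here, it differs from compound 3 by methyl in place of hydrogen on an oxygen on a saturated carbon, which is the same change as the one from compound 1 to compound 2, at the same place. Among the measured compounds shown here, only one instance of the step has been seen, so the expectation rests on a single pair. The step is expected to be a 10-fold higher number from compound 3 to compound 4 (1.00 log units; beyond the scatter), taken directly from a 13-fold higher number from compound 1 to compound 2 (1.10 log units; beyond the scatter) and slightly softened for the change of core. Compound 4 is therefore estimated at 450 nM in this assay, with a range from 130 nM to 1500 nM.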

Compound 4, half-maximal effective concentration: 5370 nM
The estimate for compound 4 lay 12-fold (1.08 log units) below the measured number; the measured number lies above the stated range.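

In this assay hydroxy to methoxy gives a 120-fold higher number from compound 3 to compound 4 (2.08 log units; beyond the scatter) and so raises the number on a second core, as it did on the first. Among these compounds, with only two pairs, this cannot show which of the differences between the two cores governs the size of the step, or whether the step would keep its direction on any further core. The direction of the change carried from one core to the other in these two pairs, but its size did not, so a step measured on one of these cores is not a reliable guide to its size on the other: the same change on two cores in this assay, a 13-fold higher number (1.10 log units; beyond the scatter) from compound 1 to compound 2 and a 120-fold higher number (2.08 log units; beyond the scatter) from compound 3 to compound 4, 9.5-fold (0.98 log units) apart, beyond the scatter of two such steps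

Still open, going by these compounds, is whether ethoxy or a longer chain on the same oxygen would separate the two cores in the same way, or whether an amine in place of the hydroxy would do so. On these data alone, it also remains open which part of the core difference goes with the larger step, since the two cores are not separated here into single changes.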